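A few compounds are considered here, and "the series" means these few. Any claim that something is new, unique, unknown or untested is made for them only; others in the source may bear on it.

Of the compounds shown here, three have been tested in an assay on HEK293 cells for inhibition of Monoacylglycerol lipase ABHD6 (Homo sapiens), read by scintillation counting, with stated times of 30 min and 5 min; on this read-out lower numbers stand for stronger inhibition and higher numbers for weaker inhibition. Compound 1 `Cc1c(Br)cc(C(=O)NC2CCNCC2)c(=O)n1Cc1ccc(F)cc1` gives only a limit of the assay, > 10000 nM. Compound 2 `Cc1c(Cl)cc(C(=O)NC2CCCCCC2)c(=O)n1Cc1ccc(F)cc1` likewise gives only a limit, > 10000 nM. Compound 3 `Cc1ccc(C(=O)NC2CCCCCC2)c(OCc2ccc(F)cc2)n1` also stands at a limit, > 10000 nM. Compound 3 therefore stands where every value shown stands, namely (the limit of > 10000 nM in this assay, at which 3 of the 3 values shown sit), and no number separates it from the others. Compound 4 `Cc1nc(OCc2ccc(F)cc2)c(C(=O)NC2CCCCCC2)cc1-c1ccc(F)cc1` differs from compound 3 in one place: 4-fluorophenyl in place of hydrogen on an aromatic carbon. Going by the values given here, with no step between measured compounds to guide the expectation, the direction of an at least 1.6-fold lower number from compound 3 to compound 4 (0.22 log units; that floor lies within the scatter) is uncertain and is expected to remain modest. Compound 4 is expected to give about 6000 nM in this assay, within 1500 nM to 25000 nM, with a fair chance that only a limit is again reported.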

Compound 4, half-maximal inhibitory concentration: > 10000 nM
Compound 4 was reported as a limit; the forecaster's own chance of this, stated with the estimate: 45%; middle value at least 1.6-fold (0.22 log units) from the limit.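

In this assay, going by these compounds alone, compound 4 gives > 10000 nM, a limit of the assay, as compound 3 also does, so no step between compound 3 and compound 4 can be read. The compounds shown leave open which change in structure, if any, would give a measurable number, with every value at one point: the limit of > 10000 nM in this assay, at which 4 of the 4 values shown sit.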